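Phenyl for 1,3-thiazol-5-yl at the assay limit

The source may report more compounds than this note shows. Statements on the series, on what has been measured and on what is new or still open speak of the compounds shown alone.

Values so far in a functional assay on A549 cells (Homo sapiens) for cytotoxicity, with a stated time of 60 h (on this read-out higher numbers stand for an effect only at larger amounts of compound and lower numbers for an effect already at smaller amounts), are these:
- Compound 1 `CCN(CC)C(=O)c1c(NC(=O)c2cccs2)sc(C)c1C` gives > 30000 nM as a limit
- Compound 2 `CCN(CC)C(=O)c1c(NC(=O)c2ccsc2)sc2c1CCCC2` gives 29400 nM as a number
- Compound 3 `CCN(CC)C(=O)c1c(NC(=O)c2cncs2)sc2c1CCCC2` gives > 30000 nM as a limit

Compound 3 yields no number and stands at the limit of > 30000 nM in this assay, at which 2 of the 3 values shown sit, as the data now show. Compound 4 `CCN(CC)C(=O)c1c(NC(=O)c2ccccc2)sc2c1CCCC2` carries phenyl in place of 1,3-thiazol-5-yl on a carbonyl carbon, with phenyl in place of 1,3-thiazol-5-yl on a carbonyl carbon as the full change. For the measured compounds named here, the only measured step on that carbonyl carbon is an at least 1.0-fold higher number from compound 2 to compound 3 (0.00 log units; that floor lies within the scatter) and it stays within the scatter. Going by that step, no change beyond the scatter is expected in this assay for this exchange. The expected size is an at least 1.0-fold lower number from compound 3 to compound 4 (0.02 log units; that floor lies within the scatter) in this estimate. For compound 4 the estimated value is 28000 nM with an expected range of 12000 nM to 50000 nM overall, and a reported limit would be no surprise.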

Compound 4, half-maximal effective concentration: > 30000 nM
Compound 4 gave a limit, no number; the forecaster's own chance of this, stated with the estimate: 55%; middle value at least 1.0-fold (0.02 log units) away from the limit.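

In this assay the exchange of thiophen-3-yl for phenyl on a carbonyl carbon gives an at least 1.0-fold higher number from compound 2 to compound 4 (0.00 log units; that floor lies within the scatter) and so shows no change beyond the scatter, now with a ring of carbon only. The step between compound 3 and compound 4 cannot be read, as both values are limits. The top of the range thus grows more crowded: the limit of > 30000 nM in this assay, at which 3 of the 4 values shown sit.

Still open, on these data alone, is whether any group on this carbonyl carbon gives a clearly lower number. A phenyl carrying an amine or a carboxylic acid is not among the compounds shown.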